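The compounds below may be only part of what the source reports. "The series", "measured", "known", "first", "only" and "open" are said of these compounds alone.

Measured in a functional assay on DU-145 cells (Homo sapiens) for inhibition, read by trypan blue exclusion, with a stated time of 96 h; on this read-out higher numbers stand for weaker inhibition of growth and lower numbers for stronger inhibition of growth: compound 1, `Cc1ccsc1/C=C(/SCc1ccc(Cl)c(Cl)c1)C(=O)c1ccc(Cl)cc1`, gives 50000 nM; compound 2, `COc1ccc(OC)c(/C=C(/SCc2ccc(Cl)c(Cl)c2)C(=O)c2ccc(Cl)cc2)c1`, gives 10000 nM.

On these two numbers compound 1 stands highest, and its nearest neighbour is compound 2, reached by a 5.0-fold lower number from compound 1 to compound 2 (0.70 log units; beyond the scatter). That step exchanges the aryl group on the double-bonded chain carbon and leaves the rest of the shared core untouched.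

Compound 3, `Cc1ccsc1/C=C(/SCc1ccc(F)cc1)C(=O)c1ccc(Cl)cc1`, is the next compound to be examined. It differs from compound 1 at another place: 4-fluorophenyl in place of 3,4-dichlorophenyl on a saturated chain carbon bound to a sulfur. Among the measured compounds shown here, the one measured step, a 5.0-fold lower number from compound 1 to compound 2 (0.70 log units; beyond the scatter), concerns the aryl on the double-bonded chain carbon, so it does not bear on a change at the saturated chain carbon bound to a sulfur. For the measured compounds named here, no measured pair shows what an exchange at that position does in this assay. With nothing to point either way, the expectation for compound 3 is a step within the scatter, a 1.2-fold higher number from compound 1 to compound 3 (0.08 log units; within the scatter), weighed slightly toward a higher number given that compound 1 already sits at the top of the range seen. Compound 3 is therefore estimated at 60000 nM, with a range from 20000 nM to 180000 nM.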

Compound 3, concentration for 50% growth inhibition: 50000 nM
Compound 3: middle estimate off by 1.2-fold (0.08 log units), on the high side; measured number inside the range.
By their numbers in this assay, from the lowest: compound 2; then compounds 1 and 3 (each within the scatter of the next).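

In this assay, among the compounds shown here, the exchange at the saturated chain carbon bound to a sulfur gives the first reading for this position: 4-fluorophenyl in place of 3,4-dichlorophenyl yields no change at the digits printed from compound 1 to compound 3 (within the scatter). On the core of compound 1, this place therefore accepts the loss of both chlorine atoms, the entry of one fluorine and one heavy atom fewer with no shift in the number, whereas the exchange on the double-bonded chain carbon gave a 5.0-fold lower number from compound 1 to compound 2 (0.70 log units; beyond the scatter). Nothing measured here offers an explanation for this lack of change.

As far as these compounds go, compound 1 and compound 3 both lie at the weak end of the numbers seen so far, so it remains open whether the same exchange would also leave the number unchanged on compound 2, which carries 2,5-dimethoxyphenyl. Also open, from the compounds shown here alone, is what a group of a different kind would do at this place, such as a 4-aminophenyl, a 4-carboxyphenyl or a longer chain in place of the 3,4-dichlorobenzyl.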